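Notes on the amine replacement from compound 2 to compound 4

The compounds below may be only part of what the source reports. "The series", "measured", "known", "first", "only" and "open" are said of these compounds alone.

Of the compounds shown here, three have numbers so far. Compound 1 `Nc1ccccc1NC(=O)c1ccc(CSC(=S)N2CCN(c3ccc(Cl)cc3)CC2)cc1` gives 44.8% in a functional assay on HeLa cells (Homo sapiens) for antiproliferative activity, read by CCK-8 assay, with a stated time of 72 h, tested at 8 uM; on this read-out higher numbers stand for a stronger effect at the one concentration tested and lower numbers for a weaker effect. Compound 2 `CCN(Cc1ccncc1)C(=S)SCc1ccc(C(=O)Nc2ccccc2N)cc1` gives 77.7% in this assay, and compound 3 `Nc1ccccc1NC(=O)c1ccc(CSC(=S)N2CCN(Cc3cccnc3)CC2)cc1` gives 78%. Compound 2 stands second highest of the three; compound 3 is its nearest neighbour and the two lie within the scatter of each other, while compound 1 lies far lower. Going by the values given here, the single step between compounds that differ in one place, a number 33.2 percentage points higher from compound 1 to compound 3 (beyond the scatter), came with (pyridin-3-yl)methyl in place of 4-chlorophenyl on an amine nitrogen in a ring.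

Compound 4 `Nc1ccccc1NC(=O)c1ccc(CSC(=S)N2CCc3ccccc32)cc1` has not been measured. It differs from compound 2 by 2,3-dihydro-1H-indol-1-yl in place of ethyl((pyridin-4-yl)methyl)amino on a thiocarbonyl carbon. The group that leaves carries the six-membered aromatic ring with a hetero atom and the hydrogen-bond acceptor; the group that enters carries a six-membered aromatic ring of carbon only and no acceptor. The step from compound 1 to compound 3 bears on this, in that the compound whose amine on the thiocarbonyl carbon carries a carbon-only aromatic ring, compound 1, gave the low number 44.8%, while the pyridine-bearing compound 2 gave 77.7% and compound 3 gave 78%. Among the compounds with values here, the change is not the same, and the 2,3-dihydro-1H-indol-1-yl group has no direct precedent here, so a drop of moderate size in this assay is expected, estimated as a number 22.7 percentage points lower from compound 2 to compound 4 (beyond the scatter). Compound 4 is therefore expected to give 55%, within the range 35% to 75%.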

Compound 4, a percentage reported as inhibition, at one concentration (the size of the read-out at that concentration, not a potency): 67%
The estimate for compound 4 lay 12 percentage points below the measured number, within the range that was stated.
By their numbers in this assay, from the lowest: compound 1; then compound 4; then compounds 2 and 3 (each within the scatter of the next).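

In this assay the step of a number 10.7 percentage points lower from compound 2 to compound 4 (beyond the scatter) is beyond the scatter but modest, so at the thiocarbonyl carbon the pyridine ring and its hydrogen-bond acceptor can be given up, with the amine closed into 2,3-dihydro-1H-indol-1-yl, at a measurable but limited cost. Going by these compounds alone, the earlier compounds had linked the one low number to a carbon-only aromatic ring on the amine, but among the amines on this carbon, compound 1 gives 44.8% and compound 4 gives 67%, so compound 4 goes against that reading and such a ring does not by itself bring the number down to the level of compound 1. No measurement is at hand that accounts for the size of this step or says which part of the change produced it.

Compound 4 alters the ring type, the acceptor count and the open or closed form of the amine all at once, so these contributions remain unseparated. An ethyl(benzyl)amino group on the same thiocarbonyl carbon would isolate the pyridine ring from the ring closure, and an indol-1-yl analogue carrying a chlorine on its benzene ring would test how far the contrast with compound 1 extends.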